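The source may report more compounds than this note shows. Statements on the series, on what has been measured and on what is new or still open speak of the compounds shown alone.

Compound 2 `O[C@@H]1Cc2ccccc2N[C@H](c2c(Cl)cccc2Cl)C1` is the starting point in an ADME assay on Vero cells (Chlorocebus sabaeus) for cytotoxicity, read by MTT assay, with a stated time of 72 h; a higher number here means that more compound is tolerated, a lower number that less compound is tolerated. For compound 2 the assay returns only a limit, > 300000 nM. Compound 3 `O[C@@H]1Cc2ccccc2N[C@H](c2c(F)cccc2Cl)C1` likewise stops at a limit, > 300000 nM. Compound 1 `O[C@@H]1Cc2cc(Cl)ccc2N[C@H](c2ccccc2Cl)C1` gives a readable value in this assay, 106000 nM. Within the data shown here, the single measured step between neighbours, a step that the two limits leave unreadable from compound 2 to compound 3, stays unreadable because of the limit of > 300000 nM in this assay, at which 2 of the 3 values shown sit. Compound 4 `O[C@@H]1Cc2cc(Cl)ccc2N[C@H](c2c(Cl)cccc2Cl)C1` differs from compound 2 by chloro in place of hydrogen on an aromatic carbon. Compound 1 already carries that chloro and gives 106000 nM in this assay. Among the measured compounds shown here, no measured step therefore reports this change directly. The estimate for compound 4 is 150000 nM, expected to lie between 60000 nM and 400000 nM. That expectation corresponds to a step of an at least 2.0-fold lower number from compound 2 to compound 4 (0.30 log units; that floor lies within the scatter), with a real chance that this assay again reports only a limit.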

Compound 4, half-maximal cytotoxic concentration: 49900 nM
Beside the measured number, compound 4's estimate is 3.0-fold (0.48 log units) above it; measured number below the stated range.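

In this assay, among these compounds, chloro in place of hydrogen on an aromatic carbon, meta to a fused ring and para to a fused ring, gives an at least 6.0-fold lower number from compound 2 to compound 4 (0.77 log units; beyond the scatter), the first readable change at this position. The same exchange at a different aromatic carbon gives a 2.1-fold lower number from compound 1 to compound 4 (0.33 log units; beyond the scatter). The first step has only a floor for its size, since compound 2 stands at a limit: the limit of > 300000 nM in this assay, at which 2 of the 4 values shown sit.

The compounds shown leave open whether a fluoro, a methyl or an amine at this position would lower the number in the same way. They also leave open whether the chloro acts alike with the fluoro of compound 3 in place.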